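Swapping a nitro-bearing ring for a dichlorophenyl ring

The source may report more compounds than this note shows. Statements on the series, on what has been measured and on what is new or still open speak of the compounds shown alone.

Measured compounds and values:
compound 1, `O=C(/C=C/c1ccc(Oc2ncnc3ccc(Cl)cc23)cc1)/C=C/c1cc([N+](=O)[O-])ccc1Cl`: 76.8%
compound 2, `O=C(/C=C/c1cc([N+](=O)[O-])ccc1Cl)/C=C/c1ccccc1Oc1ncnc2ccc(Cl)cc12`: 86.9%

Of the compounds shown here, two have been tested in a functional assay on PC-3 cells (Homo sapiens) for inhibition, read by MTT assay, with a stated time of 72 h, tested at 10 uM; on this read-out lower numbers stand for less inhibition of growth and higher numbers for more inhibition of growth at the one concentration tested. Compound 1 gives 76.8% in this assay, the lower of the two numbers. Compound 2, which shares the same kind of building blocks arranged differently, gives 86.9% in this assay, a number that lies beyond the usual scatter above compound 1. Among the compounds with values here, the two measured compounds differ in more than one place, so no single structural step between them can be read off.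

Compound 3, `O=C(/C=C/c1ccc(Oc2ncnc3ccc(Cl)cc23)cc1)/C=C/c1cccc(Cl)c1Cl`, has not yet been measured. It differs from compound 1 in one place: 2,3-dichlorophenyl in place of 2-chloro-5-nitrophenyl on a double-bonded chain carbon bound to a double-bonded chain carbon. Without any measured step of this kind to lean on, the expectation rests on compound 1 alone. Both compounds keep the shared core and the chain that carries the two rings, so the expected step of a number 4.8 percentage points lower from compound 1 to compound 3 (within the scatter) is small, within the scatter, with a slight lean downward. Compound 3 is therefore estimated to give 72% in this assay, within a range from 55% to 88%.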

Compound 3, percent growth inhibition at one concentration: 67.4%
Compound 3: middle estimate off by 4.6 percentage points, on the high side; measured number inside the range.
By their numbers in this assay, from the lowest: compounds 3 and 1 (each within the scatter of the next); then compound 2.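

This is the only step shown that changes a single place, so it can be read directly: in this assay, putting 2,3-dichlorophenyl in place of 2-chloro-5-nitrophenyl on a double-bonded chain carbon bound to a double-bonded chain carbon gives a number 9.4 percentage points lower from compound 1 to compound 3 (within the scatter). At this place, then, the nitro-bearing ring can be exchanged for a dichlorophenyl ring with no change that stands clear of the usual scatter of repeated measurements, even though the entering ring has 0 hydrogen-bond acceptors and the leaving ring has 2. No measurement shown here explains this result. The compounds shown leave open how other groups at this place would read, for example a phenyl ring carrying an amine or a carboxylic acid in place of the chlorines. Also open, as far as these compounds go, is whether the same exchange would give a similar step on compound 2, which differs from compound 1 in more than one place, and whether a step of this size would hold at concentrations other than the one tested.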